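Removing the 4-aminobutyl chain from compound 2

The source may report more compounds than this note shows. Statements on the series, on what has been measured and on what is new or still open speak of the compounds shown alone.

In an ADME assay on microsomes from liver (Rattus norvegicus) for metabolic stability, using NADPH, with a stated time of 10 min (on this read-out higher numbers stand for a more stable compound and lower numbers for a less stable compound), compound 2 (`NCCCCN(C[C@@H]1Cc2ncccc2CN1)[C@H]1CCCc2cccnc21`) gives 55%. Its value lies within the usual scatter of both its neighbours: compound 1 (`NCCCCN(C[C@H]1Cc2ncccc2CN1)[C@H]1CCCc2cccnc21`) at 64% and compound 3 (`NCCCCN(C[C@H]1Cc2nccnc2CN1)[C@H]1CCCc2cccnc21`) at 50%. The next compound to be tested is compound 4 (`CN(C[C@@H]1Cc2ncccc2CN1)[C@H]1CCCc2cccnc21`), and its change from compound 2 is large: hydrogen in place of 3-aminopropyl on a saturated chain carbon bound to an amine nitrogen. Put more simply, the 4-aminobutyl chain gives way to methyl.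

Going by the values given here, only one measured step connects two close relatives here: a number 9 percentage points lower from compound 1 to compound 2 (within the scatter). It stays within the scatter, and the fact that compounds 1 and 2 differ only in the configuration as drawn shows that it involves configuration alone. That step leaves the chain untouched, so no measurement shows what removing the chain does in this assay. No direction can be argued from these data, so the expectation stays close to the value of compound 2 at 55%, with wide margins.

The expected change is no change at the digits printed from compound 2 to compound 4 (within the scatter), which is no step beyond the scatter.

For compound 4, the estimated value is 55%, with an expected range from 30% to 80%.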

Compound 4, percent of the compound remaining: 1%
Beside the measured number, compound 4's estimate is 54 percentage points above it; measured number below the stated range.
By their numbers in this assay, from the lowest: compound 4; then compounds 3, 2 and 1 (each within the scatter of the next, the first and the last beyond it).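

In this assay, going by these compounds alone, exchanging the 4-aminobutyl chain for methyl gives a number 54 percentage points lower from compound 2 to compound 4 (beyond the scatter), the first step that lies beyond the scatter. The core and the configuration as drawn stay those of compound 2, so this single change at a saturated chain carbon bound to an amine nitrogen accounts for the whole step, and the read-out is clearly sensitive to what sits at this place. The measurements give no reason why the chain change has so large an effect.

From the compounds shown here alone, with only the 4-aminobutyl chain and methyl at this place, it stays open whether a plain butyl chain without the amine, or a shorter 2-aminoethyl chain, would read close to compound 2 or close to compound 4. Going by these compounds, it is also open whether methyl would have a similar effect on the core of compound 3.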